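This account rests on a few compounds, and the source may have more. Where it says the series, first, only, none or still open, it means among the compounds named here.

Among the measured compounds shown here, in a functional assay on HeLa cells (Homo sapiens) for antiproliferative activity, read by MTT assay, with a stated time of 48 h (a lower number here means a stronger inhibitor, a higher number a weaker inhibitor), compound 1 `COc1ccc2nc(NC(c3cn(-c4ccccc4)nc3-c3ccc([N+](=O)[O-])cc3)c3c(O)ccc4ccccc34)sc2c1` gives 5540 nM and compound 2 `COc1ccc2nc(NC(c3cn(-c4ccccc4)nc3-c3cccc(I)c3)c3c(O)ccc4ccccc34)sc2c1` gives 6240 nM, so compound 2 sits level with the only other measured compound. Compound 3 `COc1cccc(-c2nn(-c3ccccc3)cc2C(Nc2nc3ccc(OC)cc3s2)c2c(O)ccc3ccccc23)c1` carries methoxy in place of iodo on an aromatic carbon, a difference counted as methoxy in place of iodo on an aromatic carbon. For the measured compounds named here, the one measured step that bears on this is a swap on the same phenyl group, a 1.1-fold higher number from compound 1 to compound 2 (0.05 log units; within the scatter), and it stays within the scatter. On that single step, no change beyond the scatter is expected in this assay. The expected step is a 1.1-fold lower number from compound 2 to compound 3 (0.05 log units; within the scatter). For compound 3, the estimated value is 5500 nM, with an expected range of 2300 nM to 13000 nM.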

Compound 3, half-maximal inhibitory concentration: 10500 nM
For compound 3 the middle estimate is 1.9-fold (0.28 log units) below the measured one; measured number inside the range.
By their numbers in this assay, from the lowest: compounds 1, 2 and 3 (each within the scatter of the next).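

In this assay methoxy in place of iodo gives a 1.7-fold higher number from compound 2 to compound 3 (0.23 log units; within the scatter) and 3-methoxyphenyl in place of 4-nitrophenyl gives a 1.9-fold higher number from compound 1 to compound 3 (0.28 log units; within the scatter) and both steps stay within the scatter. A third group on this phenyl ring, one that counts a hydrogen-bond acceptor where iodo counts none, therefore still cannot be told apart from the other two. No measurement shown here explains these numbers. Going by these compounds, whether an amine or a carboxylic acid on this phenyl ring would move the number beyond the scatter stays open. So does the effect of changes elsewhere on the shared core.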